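Shortening the side chain of compound 1: expected cytotoxicity

The source may report more compounds than this note shows. Statements on the series, on what has been measured and on what is new or still open speak of the compounds shown alone.

For the measured compounds named here, compound 1 `CCCCCCCc1cc2cn(COCCO)c(=O)nc2o1` is the only compound in this set with a numeric reading in a functional assay on HEL cells (Homo sapiens), read by microscopy; on this read-out lower numbers stand for higher toxicity in this test and higher numbers for lower toxicity in this test; in that test compound 1 gives 400000 nM. The other two compounds reach only limits. Compound 2 `CO[C@H]1[C@H](O)[C@@H](O)[C@@H](O)O[C@@H]1C(=O)O` in this assay gives > 100000 nM, which is a limit of the test and not a number. Compound 3 `C#Cc1cn(COCCO)c(=O)[nH]c1=O` in this assay gives > 400000 nM, again a limit rather than a number. Going by the values given here, these two limits are the limit of > 100000 nM in this assay, at which 1 of the 3 values shown sits, and (the limit of > 400000 nM in this assay, at which 1 of the 3 values shown sits), so compound 1 stands alone as the one measured value, and it already sits at the end of the scale that means low toxicity.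

Compound 4 `CCCCc1cc2cn(COCCO)c(=O)nc2o1` differs from compound 1 by hydrogen in place of propyl on a saturated chain carbon, four bonds along the chain from an aromatic carbon. Among the compounds with values here, no step between two measured compounds is available to size such a change. Compound 4 is expected to stay close to compound 1 in this assay, with a step of no change at the digits printed from compound 1 to compound 4 (within the scatter) that is not expected to go beyond the scatter. Compound 4 is therefore estimated at 400000 nM, within a range from 150000 nM to 1000000 nM, and a limit reading is quite possible for compound 4.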

Compound 4, minimum cytotoxic concentration: > 400000 nM
Compound 4: only a limit was reported; the forecaster's own chance of this, stated with the estimate: 45%; the middle value lies on the limit itself.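

Hydrogen in place of propyl gives the first view of this place on the saturated chain: in this assay the change gives a number no lower from compound 1 to compound 4 (the limit leaves the size open) and so moves no reading toward the toxic end of the scale. Compound 4 reads as a limit of the test and not as a number, so the size of this step cannot be read. Compound 4 thereby joins the highest limit shown here: the limit of > 400000 nM in this assay, at which 2 of the 4 values shown sit.

As far as these compounds go, what stays open is how far compound 1 and compound 4 truly lie apart, and whether a chain longer than that of compound 1 would bring a lower reading in this assay on the shared core. Equally open, from the compounds shown here alone, is what an amine or a carboxylic acid at the end of this chain would do to that reading.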